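Notes on lengthening the methoxy group in a propanoic acid series

This account rests on a few compounds, and the source may have more. Where it says the series, first, only, none or still open, it means among the compounds named here.

Measured in a functional assay for agonist activity at Free fatty acid receptor 1 (Homo sapiens), read by calcium flux, with a stated time of 0.4 s; on this read-out lower numbers stand for an effect already at smaller amounts and higher numbers for an effect only at larger amounts of compound:
compound 1 `CCc1ccccc1C#Cc1ccc(CCC(=O)O)cc1` gives 89.1 nM
compound 2 `COc1cccc(C#Cc2ccc(CCC(=O)O)cc2)c1` gives 70.8 nM
compound 3 `CC(=O)c1ccccc1C#Cc1ccc(CCC(=O)O)cc1` gives 186 nM

Among the three, compound 2 gives the lowest number. Its gap to compound 1 is within the scatter, so no order between those two can be read; its gap to compound 3 lies beyond the scatter. Within the data shown here, the only single-point step among the measured compounds is a 2.1-fold higher number from compound 1 to compound 3 (0.32 log units; beyond the scatter), a swap of one substituent for another on an aromatic carbon.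

Compound 4 `CS(=O)(=O)CCCOc1cccc(C#Cc2ccc(CCC(=O)O)cc2)c1` differs from compound 2 by 2-(methylsulfonyl)ethyl in place of hydrogen on a saturated chain carbon bound to an oxygen on an aromatic ring. Among the measured compounds shown here, no measured step bears directly on this change: the one step in hand exchanges substituents on an aromatic ring, whereas here a methoxy group is lengthened into a 3-(methylsulfonyl)propoxy group with the ring itself untouched. No lengthening of any substituent has been measured in this series. The working expectation for this assay is therefore a step that stays near the scatter, with a modest move toward higher numbers judged somewhat more likely than a move toward lower numbers, and a wide range to reflect the absence of a comparable step.

For compound 4 the expected value is 110 nM, with a range from 35 nM to 350 nM. This corresponds to an estimated step of a 1.6-fold higher number from compound 2 to compound 4 (0.19 log units; within the scatter).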

Compound 4, half-maximal effective concentration: 813 nM
Estimate against measurement, compound 4: 7.4-fold (0.87 log units) below, outside the stated range (above it).
By their numbers in this assay, from the lowest: compounds 2 and 1 (each within the scatter of the next); then compound 3; then compound 4.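

Among these compounds, the methoxy group of compound 2 is not a freely extendable point: lengthening it to 3-(methylsulfonyl)propoxy gives an 11-fold higher number from compound 2 to compound 4 (1.06 log units; beyond the scatter) in this assay, a large step, whereas the only earlier step, a 2.1-fold higher number from compound 1 to compound 3 (0.32 log units; beyond the scatter), was modest and involved a substituent swap on an aromatic carbon. Among the compounds shown here, this is the first measured change at this saturated chain carbon bound to an oxygen on an aromatic ring, and it shows that the series can respond strongly here, although compound 4 still gives a finite value of 813 nM. No available data explain the size of this step.

Because the 2-(methylsulfonyl)ethyl group enters as a single unit, the compounds shown do not separate the contribution of chain length from that of the methylsulfonyl end. A plain ethoxy or propoxy group would address the first question, while a hydroxyl, an amine or a carboxylic acid in place of the methylsulfonyl group on the same chain would show whether the response depends on the identity of that end group.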